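Isobutoxy versus hydroxy on the anilide at two chain lengths

The compounds below may be only part of what the source reports. "The series", "measured", "known", "first", "only" and "open" are said of these compounds alone.

Compound 1 `CC(C)COc1ccc(NC(=O)CCCCCCCSc2nnc(Cc3nn(C)c(=O)c4ccccc34)n2C)cc1` gives 4800 nM in an assay on isolated protein (Mus musculus) for inhibition of IL15-IL15 receptor (Homo sapiens), read by resazurin assay, with stated times of 30 min and 2.5 days; a lower number here means a stronger inhibitor, a higher number a weaker inhibitor. Compound 3 `Cn1c(Cc2nn(C)c(=O)c3ccccc23)nnc1SCCCCCCCC(=O)Nc1ccc(O)cc1` reaches only a limit of this assay, > 30000 nM. That limit, (the limit of > 30000 nM in this assay, at which 1 of the 3 values shown sits), is where the hydroxy analogue with the long chain sits. The change from compound 3 to compound 1 is isobutyl in place of hydrogen on an oxygen on an aromatic ring, and it brings an at least 6.2-fold lower number from compound 3 to compound 1 (0.79 log units; beyond the scatter). Compound 2 `Cn1c(Cc2nn(C)c(=O)c3ccccc23)nnc1SCC(=O)Nc1ccc(O)cc1` is reported as "not active" (no number reported) in this assay. The difference between the cores of compound 2 and compound 3 is not broken down here. Compound 4 `CC(C)COc1ccc(NC(=O)CSc2nnc(Cc3nn(C)c(=O)c4ccccc34)n2C)cc1` is not yet measured; it differs from compound 2 by isobutyl in place of hydrogen on an oxygen on an aromatic ring, the same change as from compound 3 to compound 1, at the same place. Compound 2 gives no number, so the earlier step cannot be carried over as a figure; a shift in the same direction is expected. Compound 4 is expected to give about 15000 nM in this assay, estimated between 3000 nM and 60000 nM.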

Compound 4, half-maximal inhibitory concentration: 30000 nM
For compound 4 the middle estimate is 2.0-fold (0.30 log units) below the measured one, within the range that was stated.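

Going by these compounds alone, compound 2 has no number in this assay, and no step from it to compound 4 can be read. Going by these compounds, the size of the hydroxy to isobutoxy change in this pair remains open, as does any comparison with the same change at the longer chain.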